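From compound 3 to compound 4 in one side chain

The source may hold more compounds than are shown below. What is called first, only, known or untested is meant among the compounds shown, and "the series" means these compounds.

- compound 1 `CCn1c(C(=O)N[C@H](CO)C(C)C)ccc1C(CC)(CC)c1ccc(OCS(=O)(=O)c2ccccc2)c(C)c1` gives 25500 nM
- compound 2 `CCn1c(C(=O)N[C@@H](CO)C(C)C)ccc1C(CC)(CC)c1ccc(OCS(=O)(=O)c2ccccc2)c(C)c1` gives 18800 nM
- compound 3 `CCn1c(C(=O)N[C@@H](C)C(=O)O)ccc1C(CC)(CC)c1ccc(OCS(=O)(=O)c2ccccc2)c(C)c1` gives 35500 nM

These values come from a functional assay on MCF7 cells (Homo sapiens) for antiproliferative activity, read by MTT assay, with a stated time of 24 h (on this read-out higher numbers stand for weaker inhibition and lower numbers for stronger inhibition), and all lie within the scatter of one another. Compound 3 therefore cannot be set apart from the other two: the step of a 1.4-fold higher number from compound 1 to compound 3 (0.14 log units; within the scatter) and the step of a 1.9-fold higher number from compound 2 to compound 3 (0.28 log units; within the scatter) both stay within the scatter. So does the step of a 1.4-fold lower number from compound 1 to compound 2 (0.13 log units; within the scatter), which goes with the fact that compounds 1 and 2 differ only in the configuration as drawn in this pair.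

Compound 4 `CCn1c(C(=O)N[C@H](CC(=O)O)C(=O)O)ccc1C(CC)(CC)c1ccc(OCS(=O)(=O)c2ccccc2)c(C)c1` differs from compound 3 at one place: 1,2-dicarboxyethyl in place of 1-carboxyethyl on an amide-type nitrogen. In words, 1,2-dicarboxyethyl stands in place of 1-carboxyethyl on an amide-type nitrogen. The closest evidence is the exchange at that same nitrogen, seen in the step of a 1.9-fold higher number from compound 2 to compound 3 (0.28 log units; within the scatter) and the step of a 1.4-fold higher number from compound 1 to compound 3 (0.14 log units; within the scatter). Neither left the scatter, so no step beyond the scatter is expected in this assay. The expected step is a 1.1-fold higher number from compound 3 to compound 4 (0.05 log units; within the scatter). For compound 4 the estimated value is 40000 nM, with an expected range from 18000 nM to 90000 nM.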

Compound 4, half-maximal inhibitory concentration: > 50000 nM
Compound 4: only a limit was reported; the forecaster's own chance of this, stated with the estimate: 15%; middle value at least 1.2-fold (0.09 log units) away from the limit.
By their numbers in this assay, from the lowest: compounds 2, 1 and 3 (each within the scatter of the next). At a limit, above all of these: compound 4.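

In this assay compound 4 is reported only as a limit, > 50000 nM. Even so, the 1,2-dicarboxyethyl group on the amide-type nitrogen gives the only step shown that is beyond the scatter, an at least 2.6-fold higher number from compound 2 to compound 4 (0.42 log units; beyond the scatter), while the floors of an at least 1.4-fold higher number from compound 3 to compound 4 (0.14 log units; that floor lies within the scatter) and an at least 1.9-fold higher number from compound 1 to compound 4 (0.29 log units; that floor lies within the scatter) stay within it. Among the compounds shown here, this position therefore tolerated the earlier exchanges without a readable change, and only this new group separates from any earlier compound, and from compound 2 alone.

As far as these compounds go, how far compound 4 lies past its limit stays open, so the true size of all three steps is unknown. Also open, from the compounds shown here alone, is whether the added carboxylic acid itself matters, which a chain of the same length ending in an amine could help to show.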